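From Chlorobenzyl to Bromobenzyl: A Single Halogen Swap

A few compounds are considered here, and "the series" means these few. Any claim that something is new, unique, unknown or untested is made for them only; others in the source may bear on it.

Compound 1 `COc1ccc(CN(c2cc(OC)c(OC)c(OC)c2)S(=O)(=O)c2ccccc2)cc1`: in a functional assay on PC-3 cells (Homo sapiens) for inhibition, read by MTT assay, with a stated time of 48 h (a higher number here means a weaker inhibitor, a lower number a stronger inhibitor), compound 1 gives only a limit, > 50000 nM.
Compound 2 `COc1cc(N(Cc2ccc(Cl)cc2)S(=O)(=O)c2ccc(C)cc2)cc(OC)c1OC`: in this assay compound 2 gives 14600 nM.

Going by the values given here, compound 2 carries the only number measured here; the other result for compound 1 is a limit of the assay and not a number, as the line the limit of > 50000 nM in this assay, at which 1 of the 2 values shown sits, shows. Compound 3 `COc1cc(N(Cc2ccc(Br)cc2)S(=O)(=O)c2ccc(C)cc2)cc(OC)c1OC` differs from compound 2 by bromo in place of chloro on an aromatic carbon, a change that reads as bromo in place of chloro on an aromatic carbon, or 4-chlorobenzyl to 4-bromobenzyl one bond further out. Among the compounds with values here, no pair of measured compounds shows this step, so its size is not known from the data. The expectation is a step from compound 2 to compound 3 that stays within the usual scatter, with no clear direction, so the estimated step is a 1.2-fold lower number from compound 2 to compound 3 (0.09 log units; within the scatter). For compound 3 the estimated value in this assay is 12000 nM, with a range from 5000 nM to 35000 nM.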

Compound 3, half-maximal inhibitory concentration: 4680 nM
For compound 3 the middle estimate is 2.6-fold (0.41 log units) above the measured one; measured number outside the range, below it.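

In this assay, the swap of chloro for bromo gives a 3.1-fold lower number from compound 2 to compound 3 (0.49 log units; beyond the scatter). Compound 2 and compound 3 are the only pair shown that differ in one place, and they show that this position, on an aromatic carbon para to a large group, responds to the identity of the halogen, even though the change alters no ring, adds no hydrogen-bond donor or acceptor, and leaves the net charge unchanged. Nothing shown here accounts for the size of this step.

Going by these compounds, a single pair of halogens sets no trend, so it remains open how iodo or fluoro would read at this position. On these data alone, it is equally open whether an amine or a carboxylic acid could take the halogen's place on the ring.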